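Chain exchange from compound 1 to compound 3

A few compounds are considered here, and "the series" means these few. Any claim that something is new, unique, unknown or untested is made for them only; others in the source may bear on it.

compound 1 `CCCCCCCCCCCCCCCc1cc(=O)c2c(O)c(C)c(OCOC)cc2o1` | > 67200 nM (a limit)
compound 2 `CCCCCCCCCCCCCCCc1cc(=O)c2c(O)c(C)c(O)cc2o1` | 43200 nM

The read-out here is a functional assay on MCF7 cells (Homo sapiens) for antiproliferative activity, read by MTT assay (on this read-out lower numbers stand for stronger inhibition and higher numbers for weaker inhibition), throughout. Compound 1 sits at the limit of > 67200 nM in this assay, at which 1 of the 2 values shown sits, so its place on the scale is known only as a limit. Going by the values given here, the only measured step is an at least 1.5-fold lower number from compound 1 to compound 2 (0.19 log units; that floor lies within the scatter), with hydrogen in place of methoxymethyl on an oxygen on an aromatic ring.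

Compound 3 `CC/C=C\C/C=C\C/C=C\CCCCCCCc1cc(=O)c2c(O)c(C)c(OCOC)cc2o1` keeps the methoxymethyl of compound 1 and differs in the chain: a group of 10 heavy atoms (10 carbon; no ring) in place of a group of 8 heavy atoms (8 carbon; no ring), on a saturated chain carbon, seven bonds along the chain from an aromatic carbon. Among the compounds with values here, no measured step touches the chain, and the one step available concerns another part of the molecule. Compound 2 at 43200 nM remains the nearest actual number, and it carries the same methoxymethyl-free core rather than the new chain. No step beyond the scatter is therefore expected in this assay, in either direction. The expected size is an at least 1.2-fold lower number from compound 1 to compound 3 (0.08 log units; that floor lies within the scatter), which is an estimate only, and a reading reported as a limit is about as likely as a number. For compound 3 the estimated value is 55000 nM, with an expected range from 20000 nM to 110000 nM in this estimate.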

Compound 3, half-maximal inhibitory concentration: 17500 nM
Estimate against measurement, compound 3: 3.1-fold (0.50 log units) above; measured number below the stated range.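

In this assay, the chain is the only place in this series where a change gives a step printed as beyond the scatter: the exchange of octyl for the group with 3 double bonds outside aromatic rings, on a saturated chain carbon, seven bonds along the chain from an aromatic carbon, gives an at least 3.8-fold lower number from compound 1 to compound 3 (0.58 log units; beyond the scatter). Going by these compounds alone, the earlier change on the oxygen, an at least 1.5-fold lower number from compound 1 to compound 2 (0.19 log units; that floor lies within the scatter), established no such step, so this result is the first sign that the series responds to the chain while the methoxymethyl stays in place. The true size of the new step may be larger than its printed floor because compound 1 is reported only as a limit: the limit of > 67200 nM in this assay, at which 1 of the 3 values shown sits.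

The change brings more chain carbons and the double bonds together, so the compounds shown cannot separate the two, and a fully saturated chain of the same length as in compound 3 would be the direct test. Also open, going by these compounds, is how the chain of compound 3 behaves with a free hydroxyl in place of the methoxymethyl, or with a carboxylic acid at the chain end.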